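The source may report more compounds than this note shows. Statements on the series, on what has been measured and on what is new or still open speak of the compounds shown alone.

Measured compounds: compound 1 `Cc1cc(C)cc(S(=O)(=O)c2c(C(=O)NCC(=O)NC(C)c3ccccc3)[nH]c3ccc(Cl)cc23)c1`, compound 2 `Cc1cc(C)cc(S(=O)(=O)c2c(C(=O)NC(C)C(=O)NCCn3c(C)cnc3[N+](=O)[O-])[nH]c3ccc(Cl)cc23)c1`, compound 3 `Cc1cc(C)cc(S(=O)(=O)c2c(C(=O)NCC(=O)NCc3ccco3)[nH]c3ccc(Cl)cc23)c1`.

In an ADME assay on MT4 cells (Homo sapiens) for cytotoxicity, read by MTT assay (a higher number here means that more compound is tolerated, a lower number that less compound is tolerated), compound 1 gives 29400 nM. Compound 2 gives 16000 nM. For compound 3 this assay returns only a limit, > 50000 nM. Compound 2 and compound 1 sit within the scatter of one another, so no order between them is claimed.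

The unmeasured compound 4 `Cc1cc(C)cc(S(=O)(=O)c2c(C(=O)NC(C)C(=O)NCc3ccncc3)[nH]c3ccc(Cl)cc23)c1` differs from compound 2 by a group of 6 heavy atoms (5 carbon, 1 nitrogen; one six-membered aromatic ring with 1 hetero atom) in place of a group of 10 heavy atoms (5 carbon, 3 nitrogen, 2 oxygen; one five-membered aromatic ring with 2 hetero atoms), on a saturated chain carbon bound to an amide-type nitrogen. Within the data shown here, the one measured step that touches the group at this end of the chain is an at least 1.7-fold higher number from compound 1 to compound 3 (0.23 log units; that floor lies within the scatter), a swap of the aromatic group on the amide-type nitrogen that did not move the number beyond the scatter, with the floor set by the limit of > 50000 nM in this assay, at which 1 of the 3 values shown sits. A change of similar size, no direction beyond the scatter, is therefore expected, a 1.6-fold higher number from compound 2 to compound 4 (0.19 log units; within the scatter). For compound 4 the estimate is 25000 nM, expected between 12000 nM and 50000 nM.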

Compound 4, half-maximal cytotoxic concentration: 19500 nM
Estimate against measurement, compound 4: 1.3-fold (0.11 log units) above; low and high end bracket the measured number.
By their numbers in this assay, from the lowest: compounds 2, 4 and 1 (each within the scatter of the next). At a limit, above all of these: compound 3.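

In this assay, pyridin-4-yl in place of the group of 10 heavy atoms, on a saturated chain carbon bound to an amide-type nitrogen, stays within the scatter: a 1.2-fold higher number from compound 2 to compound 4 (0.09 log units; within the scatter). The larger change on the amide-type nitrogen also stays within the scatter, with a 1.5-fold lower number from compound 1 to compound 4 (0.18 log units; within the scatter) as its step. Among these compounds, the only step beyond the scatter is an at least 2.5-fold lower number from compound 3 to compound 4 (0.40 log units; beyond the scatter), and it is a floor set by the limit for compound 3: the limit of > 50000 nM in this assay, at which 1 of the 4 values shown sits.

From the compounds shown here alone, the true value of compound 3 remains open. So does whether an amine or a carboxylic acid at this chain end would move the number beyond the scatter.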